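The compounds below may be only part of what the source reports. "The series", "measured", "known", "first", "only" and "open" are said of these compounds alone.

Within the data shown here, compound 2 `Cc1ccc(NC(=O)c2cc3ccccc3oc2=O)cc1` gives 710 nM in an in vitro assay on BTI-TN-5B1-4 cells for inhibition of Amine oxidase [flavin-containing] B (Homo sapiens), read by fluorescence (a higher number here means a weaker inhibitor, a lower number a stronger inhibitor), the lowest of the two numbers so far; compound 1 `CC(C)CNC(=O)c1cc2ccccc2oc1=O` gives 3270 nM. Among the measured compounds shown here, the single measured step, a 4.6-fold lower number from compound 1 to compound 2 (0.66 log units; beyond the scatter), concerns the group on the amide-type nitrogen, not the aromatic ring. Compound 3 `CC(C)c1ccc(NC(=O)c2cc3ccccc3oc2=O)cc1` differs from compound 2 by isopropyl in place of methyl on an aromatic carbon. For the measured compounds named here, no measured step bears on this change, so nothing argues for a move beyond the scatter in this assay. For compound 3 a small step at most is expected, a 1.2-fold lower number from compound 2 to compound 3 (0.07 log units; within the scatter). Compound 3 is estimated at 600 nM, with a range of 200 nM to 2000 nM.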

Compound 3, half-maximal inhibitory concentration: 650 nM
The estimate for compound 3 lay 1.1-fold (0.03 log units) below the measured number; measured number inside the range.
By their numbers in this assay, from the lowest: compounds 3 and 2 (each within the scatter of the next); then compound 1.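

Isopropyl in place of methyl on the aromatic carbon para to a large group gives a 1.1-fold lower number from compound 2 to compound 3 (0.04 log units; within the scatter) in this assay. Among these compounds, the earlier step concerned only the group on the amide-type nitrogen; this is the first reading at the aromatic carbon, and here methyl and isopropyl are not told apart. Nothing measured on hand speaks to why the number holds at this position.

On these data alone, whether an amine, a carboxylic acid or a longer chain on this aromatic carbon would move the number beyond the scatter stays open.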